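Compound 3 to compound 4: new group on nitrogen

This account rests on a few compounds, and the source may have more. Where it says the series, first, only, none or still open, it means among the compounds named here.

Measured in an ADME assay on microsomes from liver (Homo sapiens) for metabolic stability, read by LC-MS, using NADPH, with a stated time of 10 min, tested at 0.1 uM; on this read-out lower numbers stand for slow clearance and higher numbers for fast clearance:
compound 1 `CC1SC(c2cccc(C(=O)NCCCCc3ccccc3)c2)N(c2ccc(C3CC3)cc2)C1=O` gives 2010 mL.min-1.g-1
compound 2 `COc1ccc(F)cc1N1C(=O)CSC1c1cccc(C(=O)NCCCCn2cccn2)c1` gives 421 mL.min-1.g-1
compound 3 `COc1ccc(F)cc1N1C(=O)CSC1c1cccc(C(=O)NCCCCc2ccccc2)c1` gives 1250 mL.min-1.g-1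

Compound 3 lies within the scatter of compound 1 and beyond the scatter above compound 2. Compound 4 `O=C(NCCCCc1ccccc1)c1cccc(C2SCC(=O)N2c2cccc(-c3c[nH]nn3)c2)c1` has a new group in place of the 5-fluoro-2-methoxyphenyl of compound 3 (a group of 11 heavy atoms (8 carbon, 3 nitrogen; one five-membered aromatic ring with 3 hetero atoms, one six-membered aromatic ring of carbon only) in place of a group of 9 heavy atoms (7 carbon, 1 oxygen, 1 fluorine; one six-membered aromatic ring of carbon only), on an amide-type nitrogen in a ring) on an amide-type nitrogen in a ring. The entering group holds one five-membered aromatic ring with 3 hetero atoms and one six-membered aromatic ring of carbon only.

For the measured compounds named here, only one measured step is available, a 3.0-fold higher number from compound 2 to compound 3 (0.47 log units; beyond the scatter), with phenyl in place of 1H-pyrazol-1-yl on a saturated chain carbon. It was modest and does not involve this nitrogen, so it is a weak guide. Going by the values given here, no measured compound carries the entering group. Compound 2 holds a nitrogen-containing five-membered aromatic ring and gives the lower number (421 mL.min-1.g-1), so a modest move to a lower number in this assay is expected. The expected change is a 2.1-fold lower number from compound 3 to compound 4 (0.32 log units; beyond the scatter) as an uncertain estimate. Compound 4 is estimated at 600 mL.min-1.g-1 with an expected range of 220 mL.min-1.g-1 to 1500 mL.min-1.g-1 on present data.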

Compound 4, intrinsic clearance in microsomes: 261 mL.min-1.g-1
Compound 4: middle estimate off by 2.3-fold (0.36 log units), on the high side, within the range that was stated.
By their numbers in this assay, from the lowest: compounds 4 and 2 (each within the scatter of the next); then compounds 3 and 1 (each within the scatter of the next).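

In this assay, the group on the amide-type nitrogen in a ring clearly affects the read-out: the new group gives a 4.8-fold lower number from compound 3 to compound 4 (0.68 log units; beyond the scatter) in place of 5-fluoro-2-methoxyphenyl. For the compounds shown here, the end of the chain, with a 3.0-fold higher number from compound 2 to compound 3 (0.47 log units; beyond the scatter) as its only measured step, is therefore not the only place where the number moves. No available measurement explains the change at this nitrogen.

Going by these compounds, it remains open whether the five-membered aromatic ring with 3 hetero atoms accounts for the step, or whether a carboxylic acid or an amine on the six-membered aromatic ring in its place would give a similar number. Also open, on these data alone, is whether the new group on this nitrogen and 1H-pyrazol-1-yl on the chain would combine in a single compound to give a still lower number.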